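The source may report more compounds than this note shows. Statements on the series, on what has been measured and on what is new or still open speak of the compounds shown alone.

Among the compounds with values here, compound 1 `COc1cc(-c2ccc(O)c(O)c2)nc2ccccc12` is the only member of this small set with a numerical result: in a functional assay on HT-22 cells (Mus musculus), read by MTT assay, with a stated time of 24 h (on this read-out lower numbers stand for an effect already at smaller amounts and higher numbers for an effect only at larger amounts of compound), compound 1 gives 40 nM. Within the data shown here, compound 2 `COc1cc(-c2ccc(O)cc2)nc2ccccc12` in this assay is reported as "not active" (no number reported), and compound 3 `COc1cc(-c2ccc([N+](=O)[O-])c(O)c2)nc2ccccc12` in this assay is likewise reported as "not active" (no number reported); for these two no number exists, so no step from compound 1 can be stated. Compound 4 `Oc1ccc(-c2cc(OC3CCCC3)c3ccccc3n2)cc1O` keeps the shared core of compound 1 and differs only in one place: cyclopentyl in place of methyl on an oxygen on an aromatic ring. Among the measured compounds shown here, no measured pair shows what such a change does here, so the expectation rests on compound 1 alone. The step from compound 1 to compound 4 is expected to be modest, a 1.5-fold higher number from compound 1 to compound 4 (0.18 log units; within the scatter), close to or just beyond the usual scatter. Compound 4 is therefore estimated at 60 nM, with a likely range from 15 nM to 300 nM.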

Compound 4, half-maximal effective concentration: 7 nM
Beside the measured number, compound 4's estimate is 8.6-fold (0.93 log units) above it; measured number below the stated range.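

In this assay the swap on this oxygen gives a 5.7-fold lower number from compound 1 to compound 4 (0.76 log units; beyond the scatter) and so shows that a group with more carbon atoms and a ring can replace methyl here without loss of effect, with the number in fact falling. The earlier compounds shown here differ from compound 1 elsewhere and gave no view of this position. Nothing in the data shown explains the step. As far as these compounds go, whether a longer chain such as butyl, a six-membered carbon ring such as cyclohexyl, or an amine on this oxygen would do the same remains open.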